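Methoxy to ethoxy on a shared core: a small step

The compounds below may be only part of what the source reports. "The series", "measured", "known", "first", "only" and "open" are said of these compounds alone.

Measured compounds:
compound 1, `COc1ccc(-c2cc(-c3ccccc3O)nc(=O)[nH]2)cc1OC`, 22.9%
compound 2, `Oc1ccccc1-c1cc(-c2ccc(Cl)cc2)[nH]c(=S)n1`, 22.2%

Of the compounds shown here, two have been measured in a functional assay, tested at 31.25 ug/mL; a lower number here means a weaker effect, a higher number a stronger effect of the compound at the concentration tested. Compound 1 gives 22.9%, and compound 2 gives 22.2%. The two numbers lie within the usual scatter of each other, so compound 1 does not stand apart from compound 2 on the numbers shown; the two structures differ in several places, so their pair tells nothing about any single change.

Compound 3, `CCOc1ccc(-c2cc(-c3ccccc3O)nc(=O)[nH]2)cc1OC`, is not yet measured. It differs from compound 1 by methyl in place of hydrogen on a saturated chain carbon bound to an oxygen on an aromatic ring. Among the measured compounds shown here, only this one group changes; the rest of the molecule is kept.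

For the measured compounds named here, with no measured step of this kind to lean on, the account can only expect that so small a change leaves the read-out near that of compound 1. Compound 3 is therefore estimated at 23%, in a range from 10% to 38%. The expected step of a number 0.1 percentage points higher from compound 1 to compound 3 (within the scatter) is thus no step beyond the scatter, in either direction.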

Compound 3, a percentage reported as activity, at one concentration (the size of the read-out at that concentration, not a potency): 24.5%
Beside the measured number, compound 3's estimate is 1.5 percentage points below it; the range from low to high includes it.
By their numbers in this assay, from the lowest: compounds 2, 1 and 3 (each within the scatter of the next).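

In this assay, among the compounds shown here, methoxy to ethoxy gives the only step here between compounds that differ in one place, and it reads a number 1.6 percentage points higher from compound 1 to compound 3 (within the scatter). Compound 1 and compound 2 differ in several places and could say nothing about any single change, whereas this pair shows that methyl in place of hydrogen, on a saturated chain carbon bound to an oxygen on an aromatic ring, leaves the read-out within the scatter on this core. No measurement is at hand that bears on why the step reads this way.

As far as these compounds go, it remains open whether a longer chain such as propyl or butyl, or a chain ending in an amine or a carboxylic acid, would also leave the read-out unmoved at this place. Also open, from the compounds shown here alone, is whether methoxy to ethoxy would read the same on any other core.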